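The source may hold more compounds than are shown below. What is called first, only, known or untested is meant among the compounds shown, and "the series" means these compounds.

Measured compounds in this series:

compound 1 `COC(=O)/C(=C\c1ccc(O)cc1)Sc1ccnc2cc(Cl)ccc12`: 5180 nM
compound 2 `COC(=O)/C(=C\c1ccc(OC(=O)c2ccccc2OC)cc1)Sc1ccnc2cc(Cl)ccc12`: 44700 nM
compound 3 `COC(=O)/C(=C\c1ccc(OC(=O)c2cc(OC)cc(OC)c2)cc1)Sc1ccnc2cc(Cl)ccc12`: 28900 nM

In a functional assay on Jurkat E6.1 cells (Homo sapiens) for cytotoxicity, read by MTT assay, with a stated time of 24 h (on this read-out lower numbers stand for stronger inhibition and higher numbers for weaker inhibition), compound 3 holds the second highest of the three numbers; its nearest neighbour is compound 2, within the scatter, and its furthest is compound 1, the step being a 5.6-fold higher number from compound 1 to compound 3 (0.75 log units; beyond the scatter).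

Compound 4 `COC(=O)/C(=C\c1ccc(OC(=O)c2cc(OC)c(OC)cc2OC)cc1)Sc1ccnc2cc(Cl)ccc12` differs from compound 3 in one place: 2,4,5-trimethoxyphenyl in place of 3,5-dimethoxyphenyl on a carbonyl carbon.

Bearing on this step are an 8.6-fold higher number from compound 1 to compound 2 (0.94 log units; beyond the scatter) and a 5.6-fold higher number from compound 1 to compound 3 (0.75 log units; beyond the scatter), which put both esters well above the free phenol of compound 1, while a 1.5-fold lower number from compound 2 to compound 3 (0.19 log units; within the scatter) stays within the scatter. A further exchange of the aryl group on the ester is therefore expected to give no step beyond the scatter: a 1.0-fold higher number from compound 3 to compound 4 (0.02 log units; within the scatter). Compound 4 is estimated at 30000 nM, within 12000 nM to 75000 nM.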

Compound 4, half-maximal inhibitory concentration: 9650 nM
Compound 4: middle estimate off by 3.1-fold (0.49 log units), on the high side, and the stated range ends above it.
By their numbers in this assay, from the lowest: compounds 1 and 4 (each within the scatter of the next); then compounds 3 and 2 (each within the scatter of the next).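

In this assay the aryl group on this carbonyl carbon proves able to move the number, with a 3.0-fold lower number from compound 3 to compound 4 (0.48 log units; beyond the scatter) and a 4.6-fold lower number from compound 2 to compound 4 (0.67 log units; beyond the scatter), whereas compounds 2 and 3 stayed within the scatter of each other. Compound 4 at 9650 nM lies within the scatter of compound 1 at 5180 nM and so breaks the link between ester and higher number seen in compounds 2 and 3. Nothing measured here accounts for this step.

Which methoxy groups of the 2,4,5-trimethoxyphenyl group carry the step stays open. So does how an acetyl group or an aminoacyl group would read on this oxygen.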